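The source may report more compounds than this note shows. Statements on the series, on what has been measured and on what is new or still open speak of the compounds shown alone.

Measured so far:
compound 1 `CCN(C/C=C/C#CC(C)(C)C)Cc1cccc(OCCN(C)S(=O)(=O)c2nccs2)c1` — 170 nM
compound 2 `CCN(C/C=C/C#CC(C)(C)C)Cc1cccc(OCCN(C)S(=O)(=O)c2cccnc2)c1` — 150 nM

In a functional assay on HepG2 cells for inhibition of squalene monooxygenase (Homo sapiens) (a higher number here means a weaker inhibitor, a lower number a stronger inhibitor), compound 2 gives 150 nM, and compound 1 gives 170 nM; the two numbers lie within the scatter of each other, so neither compound can be called the stronger. Compound 3 `CCN(C/C=C/C#CC(C)(C)C)Cc1cccc(OCCN(C)S(=O)(=O)Cc2cccs2)c1` differs from compound 2 in one place: (thiophen-2-yl)methyl in place of pyridin-3-yl on a sulfonyl sulfur. One earlier step changed the group on the sulfonyl sulfur, a 1.1-fold lower number from compound 1 to compound 2 (0.05 log units; within the scatter), and the number barely moved. A further swap at the same place is therefore expected to give no step beyond the scatter, a 1.2-fold higher number from compound 2 to compound 3 (0.08 log units; within the scatter). Compound 3 is estimated at 180 nM, in the range 80 nM to 450 nM.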

Compound 3, half-maximal inhibitory concentration: 200 nM
Estimate against measurement, compound 3: 1.1-fold (0.05 log units) below, and the stated range covers the measured number.
By their numbers in this assay, from the lowest: compounds 2, 1 and 3 (each within the scatter of the next).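

In this assay, (thiophen-2-yl)methyl on the sulfonyl sulfur gives a 1.3-fold higher number from compound 2 to compound 3 (0.12 log units; within the scatter) and a 1.2-fold higher number from compound 1 to compound 3 (0.07 log units; within the scatter). Among these compounds, all three groups so far carry an aromatic ring, but this one is the first attached to the sulfur through a carbon rather than directly, and that difference moves the number no further than the scatter. Nothing available explains this tolerance.

Every group shown here contains an aromatic ring. Going by these compounds, how a plain methyl, a carboxylic acid or an amine on the sulfonyl sulfur would behave remains open.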